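The source may hold more compounds than are shown below. What is called first, only, known or untested is meant among the compounds shown, and "the series" means these compounds.

Measured compounds:
- compound 1, `COc1cccc(C(=O)N(C)/N=C/c2ccc(OC)c(OC)c2)c1`: 73%
- compound 2, `COc1ccc(/C=N/N(C)c2ncnc3ccccc23)cc1OC`: 47%

In a functional assay on the whole organism (lung, strain A/J) for inhibition, with Mus musculus as the target, with stated times of 1 h and 18 h, at a dose of 100 umol/kg by the oral route (a higher number here means more inhibition at the dose given (going by the name of the read-out), a lower number less inhibition), compound 1 stands highest of the two numbers. Its nearest neighbour is compound 2, whose value lies lower by a gap that goes beyond the usual scatter of repeated measurements. The two differ in more than one place, so nothing more than the two values themselves can be read from that pair.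

Compound 3, `COc1ccc(C(=O)N(C)/N=C/c2ccc(OC)c(OC)c2)cc1`, is the next point in the series. It differs from compound 1 only in the arrangement of the same atoms: 4-methoxyphenyl in place of 3-methoxyphenyl on a carbonyl carbon.

Among the compounds with values here, no step of this kind between measured compounds is available in this assay, so the size of the change is open. The expectation is a step of small size, if any, and more likely downward than upward, so the change from compound 1 to compound 3 is estimated at a number 8 percentage points lower from compound 1 to compound 3 (within the scatter). Compound 3 is expected to give about 65%, within a range of 45% to 85%, which leaves the result possibly indistinguishable from compound 1 by scatter alone.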

Compound 3, a percentage reported as inhibition, in the whole organism at one dose (the size of the read-out at that dose, not a potency): 81%
For compound 3 the middle estimate is 16 percentage points below the measured one; measured number inside the range.
By their numbers in this assay, from the lowest: compound 2; then compounds 1 and 3 (each within the scatter of the next).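

In this assay, the step to 4-methoxyphenyl in place of 3-methoxyphenyl on a carbonyl carbon is a number 8 percentage points higher from compound 1 to compound 3 (within the scatter). Within the data shown here, this is the first comparison that differs in one place, and it shows that these two arrangements of the same atoms cannot be told apart at this single dose. Nothing available bears on the reason for this result.

Still open, on these data alone, is whether a carboxylic acid, an amine or a butoxy chain on this phenyl ring would keep the read-out in the range of compound 1 and compound 3. As far as these compounds go, a read-out at one dose is not a potency, so any difference between compound 1 and compound 3 at other doses also remains open.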